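This account rests on a few compounds, and the source may have more. Where it says the series, first, only, none or still open, it means among the compounds named here.

Two compounds share one core and differ only in the group carried on the outer phenyl ring. Compound 1 `O=[N+]([O-])c1ccc(-c2cc(-c3ccccc3)nn2-c2ccccc2)cc1` bears a nitro group there; in an assay for inhibition of cathepsin H (Capra hircus), using Lineweaver-Burk analysis (a higher number here means a weaker inhibitor, a lower number a stronger inhibitor), compound 1 gives 2580 nM. Compound 2 `Cc1ccc(-c2cc(-c3ccccc3)nn2-c2ccccc2)cc1` carries a methyl in its place, and in this assay compound 2 gives 7400 nM. Going by the values given here, the only step so far, a 2.9-fold higher number from compound 1 to compound 2 (0.46 log units; beyond the scatter), puts compound 2 at the highest of the two numbers measured, with compound 1 the nearest and lower.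

Compound 3 `COc1ccc(-c2cc(-c3ccccc3)nn2-c2ccccc2)cc1` is the next member of the series. Its change from compound 2 is methoxy in place of methyl on an aromatic carbon. Among the compounds with values here, no measured step exchanges methyl for methoxy, so the one step in hand, from compound 1 to compound 2, tells only that a change at this position can move the number by a modest amount and not in which direction a methoxy would move it. Compound 3 is therefore expected to sit close to compound 2, with a step of a 1.2-fold lower number from compound 2 to compound 3 (0.09 log units; within the scatter) expected in this assay, possibly within the scatter. The estimate for compound 3 in this assay is 6000 nM, with a range from 2500 nM to 14000 nM.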

Compound 3, inhibition constant: 3330 nM
The estimate for compound 3 lay 1.8-fold (0.26 log units) above the measured number; measured number inside the range.
By their numbers in this assay, from the lowest: compounds 1 and 3 (each within the scatter of the next); then compound 2.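

In this assay, methoxy in place of methyl on this aromatic carbon gives a 2.2-fold lower number from compound 2 to compound 3 (0.35 log units; beyond the scatter), so the position responds to a second exchange, and this time the number falls rather than rises. The comparison between the other two groups is new as well: a 1.3-fold higher number from compound 1 to compound 3 (0.11 log units; within the scatter) leaves nitro and methoxy indistinguishable here, and compound 2, whose steps to both others lie beyond the scatter, is the weakest of the three, so among these compounds only the methyl stands apart, and the two groups that carry oxygen do not. Nothing in hand explains why methoxy and nitro end up so close, or why methyl differs from both.

Three groups at one place cannot show whether the oxygen matters or whether the match between nitro and methoxy is a coincidence, and an amine, a hydroxyl, a chlorine or a carboxylic acid at the same carbon would each test that reading. The compounds shown also leave open how a plain hydrogen there would compare, and whether changes elsewhere on the shared core would move the number at all.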